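Hepatocyte Stability After a Change on the Carbonyl

The compounds below may be only part of what the source reports. "The series", "measured", "known", "first", "only" and "open" are said of these compounds alone.

Compound 1 `O=C(N[C@H]1CN(S(=O)(=O)c2ccccc2)C[C@@H]1C(=O)N[C@H]1CCCNC1)c1nnc(-c2ccc(F)cc2)s1`: 1.2 uL/min
Compound 2 `O=C(N[C@H]1CN(S(=O)(=O)c2ccccc2)C[C@@H]1C(=O)N[C@H]1CCCNC1)c1cc(-c2ccccc2Cl)on1`: 8.3 uL/min

In an ADME assay on cells (Hepatocyte, Rattus norvegicus) for metabolic stability (on this read-out lower numbers stand for slow clearance and higher numbers for fast clearance), compound 2 gives 8.3 uL/min, the higher of the two numbers; compound 1 sits a step away, a 6.9-fold higher number from compound 1 to compound 2 (0.84 log units; beyond the scatter). Compound 3 `O=C(N[C@H]1CN(S(=O)(=O)c2ccccc2)C[C@@H]1C(=O)N1C[C@H]2CCNC[C@H]21)c1cc(-c2ccccc2Cl)on1` differs from compound 2 in one place: a group of 8 heavy atoms (6 carbon, 2 nitrogen; one four-membered non-aromatic ring with 1 hetero atom, one six-membered non-aromatic ring with 1 hetero atom) in place of a group of 7 heavy atoms (5 carbon, 2 nitrogen; one six-membered non-aromatic ring with 1 hetero atom), on a carbonyl carbon. Going by the values given here, the single measured step concerns the aromatic group on the other carbonyl carbon, so no step bears on this change. Compound 3 is therefore expected to stay near compound 2, with a 1.0-fold lower number from compound 2 to compound 3 (0.02 log units; within the scatter). The estimated value of compound 3 is 8 uL/min, in the range 3 uL/min to 20 uL/min.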

Compound 3, intrinsic clearance in a liver preparation (reported as CLH), per the amount of preparation that the assay uses: 4.7 uL/min
Compound 3: the middle estimate sits 1.7-fold (0.23 log units) above what was measured; low and high end bracket the measured number.
By their numbers in this assay, from the lowest: compound 1; then compounds 3 and 2 (each within the scatter of the next).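

In this assay, putting the group with a four-membered and a six-membered non-aromatic ring in place of (piperidin-3-yl)amino gives a 1.8-fold lower number from compound 2 to compound 3 (0.25 log units; within the scatter). Going by these compounds alone, this is the first reading at this position, and the change in the amine group on this carbonyl carbon leaves the number within the scatter. No available evidence accounts for this result.

The compounds shown leave open whether an open-chain amine or a carboxylic acid here would move intrinsic clearance beyond the scatter. They also leave open whether this result holds with the aromatic group of compound 1 on the other carbonyl carbon.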